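A few compounds are considered here, and "the series" means these few. Any claim that something is new, unique, unknown or untested is made for them only; others in the source may bear on it.

Measured compounds:
- compound 1 `CC(=O)Oc1cccc2cc(-c3cccs3)c(=O)oc12`; in a functional assay on isolated protein for antagonist activity at adenosine receptor A2b (Homo sapiens) (on this read-out higher numbers stand for weaker inhibition and lower numbers for stronger inhibition), compound 1 gives > 30000 nM, which is a limit of the assay, not a number.
- compound 2 `CC(=O)Oc1ccc2cc(-c3cccs3)c(=O)oc2c1OC(C)=O`; in this assay compound 2 gives > 30000 nM, again a limit and not a number.

Among the compounds with values here, compound 1 therefore stands only as a limit in this assay, and the one further value shown is also a limit. Within the data shown here, the single measured step, a step that the two limits leave unreadable from compound 1 to compound 2, cannot be read, because of the limit of > 30000 nM in this assay, at which 2 of the 2 values shown sit.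

The next compound is compound 3 `CC(=O)Oc1cccc2cc(-c3ccsc3)c(=O)oc12`. Its change from compound 1 is thiophen-3-yl in place of thiophen-2-yl on an aromatic carbon. Among the measured compounds shown here, no measured step bears on this change: the only step known is unreadable, and nothing beyond a limit is known for compound 1. For compound 3 no movement beyond the scatter is therefore expected, and a further limit is the likelier outcome. The expected step, a step that the limit leaves unreadable from compound 1 to compound 3, is estimated at about no change. Compound 3 is estimated at 50000 nM, within 10000 nM to 300000 nM.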

Compound 3, inhibition constant: > 30000 nM
Compound 3: no number, only a limit; the forecaster's own chance of this, stated with the estimate: 80%; the middle value lies beyond the limit too.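

No step can be read from compound 1 to compound 3, thiophen-3-yl in place of thiophen-2-yl, because both stand only as limits: the limit of > 30000 nM in this assay, at which 3 of the 3 values shown sit. In this assay the compounds shown leave open whether any change on the shared core gives a readable number.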